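The compounds below may be only part of what the source reports. "The series", "measured", "known", "first", "only" and "open" are said of these compounds alone.

For the measured compounds named here, in a functional assay on A2780 cells (Homo sapiens) for cytotoxicity, read by MTT assay, with a stated time of 24 h (on this read-out higher numbers stand for weaker inhibition and lower numbers for stronger inhibition), compound 2 `CCCCC[C@@H](C[C@H](O)C[C@H]1CC=CC(=O)O1)OC` stands at 53700 nM, the higher of the two numbers measured so far. Compound 1 `CCCCC[C@@H](CCC[C@@H]1CC=CC(=O)O1)OC` gives 14900 nM, a lower number by a margin beyond the usual scatter. Neither value says much about potency on its own, since both compounds are only weak inhibitors on this read-out.

The next compound to be tested is compound 3 `CCCCC[C@@H](CCC[C@H]1CC=CC(=O)O1)OC`. It departs from compound 2 by hydrogen in place of hydroxy on a saturated chain carbon bound to two saturated chain carbons, which is hydrogen in place of hydroxy on a saturated chain carbon bound to two saturated chain carbons. Going by the values given here, no two measured compounds differ in one place alone, so the size of this change has not been observed directly. Among the compounds with values here, the only guide is compound 1, which also carries no hydroxy and gives 14900 nM. A moderate fall in the number in this assay is therefore expected, meaning stronger inhibition, though it may not clear the scatter by much. The expected change is a 2.4-fold lower number from compound 2 to compound 3 (0.39 log units; beyond the scatter). For compound 3 the estimated value is 22000 nM, with an expected range from 8000 nM to 55000 nM.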

Compound 3, half-maximal inhibitory concentration: 20600 nM
The estimate for compound 3 lay 1.1-fold (0.03 log units) above the measured number; the measured number falls inside the stated range.
By their numbers in this assay, from the lowest: compounds 1 and 3 (each within the scatter of the next); then compound 2.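

Read directly for the first time in this assay, hydrogen in place of hydroxy on a saturated chain carbon bound to two saturated chain carbons gives a 2.6-fold lower number from compound 2 to compound 3 (0.42 log units; beyond the scatter), a modest step but one that shows this position responds to the change. The stereocentre at a saturated ring carbon, drawn R in compound 1 and S in compound 3, gives a different picture, with a 1.4-fold higher number from compound 1 to compound 3 (0.14 log units; within the scatter), so inverting this centre has no effect that can be told from the scatter in the absence of the hydroxy. This pair isolates that one stereocentre, and the comparison rests on a single structural difference: the fact that compounds 1 and 3 differ only in the configuration as drawn

The compounds shown leave open whether another group on that saturated chain carbon, such as an amine or a carbonyl, would raise the number as the hydroxy does, or whether the step belongs to the hydroxy alone. They also leave open whether the stereocentre at the saturated ring carbon would remain without a readable effect with the hydroxy present, and whether a longer chain would shift any of these numbers.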